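A few compounds are considered here, and "the series" means these few. Any claim that something is new, unique, unknown or untested is made for them only; others in the source may bear on it.

Compound 3 `O=C(C(Nc1ccccc1F)c1ccc(C(F)(F)F)cc1)N1CCCC1c1ccccc1F` gives 7 nM in an assay on HEK293 cells for antagonist activity at transient receptor potential M8 protein (Canis lupus familiaris), read by fluorescence and calcium flux, with a stated time of 5 min (on this read-out higher numbers stand for weaker inhibition and lower numbers for stronger inhibition), the lowest of the three numbers recorded. Its nearest neighbour is compound 1 `O=C(C(Nc1ccccc1)c1ccc(C(F)(F)F)cc1)N1CCCC1c1ccccc1F`, which gives 30 nM; compound 2 `O=C(C(Nc1ccccc1)c1ccc(C(F)(F)F)cc1)N1CCC[C@@H]1c1ccccc1Cl` gives 168 nM and is the furthest away. The step of a 4.3-fold lower number from compound 1 to compound 3 (0.63 log units; beyond the scatter) is the only one measured, and it concerns the fluorine on the aniline ring. Compound 4 `O=C(C(Nc1ccccc1F)c1ccc(C(F)(F)F)cc1)N1CCCC1c1ccc(F)cc1` differs from compound 3 elsewhere: 4-fluorophenyl in place of 2-fluorophenyl on a saturated ring carbon. Among the measured compounds shown here, no measured pair shows what moving the fluorine on this phenyl ring does; compound 1 and compound 2 differ from each other in the halogen and the stereochemistry at that position, and their values are simply what they are. For the measured compounds named here, with no step bearing on this change, the expectation for compound 4 is a step of a 2.1-fold higher number from compound 3 to compound 4 (0.33 log units; beyond the scatter), at most modest and most likely within the scatter. Compound 4 is therefore estimated at 15 nM in this assay, within a range from 4 nM to 60 nM.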

Compound 4, half-maximal inhibitory concentration: 37 nM
The estimate for compound 4 lay 2.5-fold (0.39 log units) below the measured number; the measured number falls inside the stated range.
By their numbers in this assay, from the lowest: compound 3; then compounds 1 and 4 (each within the scatter of the next); then compound 2.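

In this assay, exchanging 2-fluorophenyl for 4-fluorophenyl on the saturated ring carbon gives a 5.3-fold higher number from compound 3 to compound 4 (0.72 log units; beyond the scatter), so the place of the fluorine on this phenyl ring matters. Among the compounds shown here, the only earlier step lay on the aniline ring, which makes this the first pair to read this position directly; the two groups match in every count given, and only the place of the fluorine differs. Nothing measured here explains the difference.

The compounds shown leave open how a plain phenyl, a pyridyl ring or a methoxy group would behave on this saturated ring carbon. Also open, going by these compounds, is whether the same step would appear on the core of compound 1, which has no fluorine on the aniline ring.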